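The compounds below may be only part of what the source reports. "The series", "measured", "known", "first", "only" and "open" are said of these compounds alone.

Compound 1 `CNC(=O)c1cc(C(=O)N[C@H]2[C@@H]3COC[C@@H]32)cc2c1OC[C@H]2c1cccnc1`: 1.4
Compound 2 `CNC(=O)c1cc(C(=O)N[C@H]2C[C@@H]2C)cc2c1OC[C@H]2c1ccccc1`: 4.5

In a physicochemical assay for lipophilicity, at pH 7.4 (on this read-out lower numbers stand for lower lipophilicity and higher numbers for higher lipophilicity), compound 1 stands lowest of the two numbers; compound 2 lies far higher, beyond the scatter, but these two compounds differ in several places at once, so no single step can be read from them. Compound 3 `CNC(=O)c1cc(C(=O)N[C@H]2[C@@H]3COC[C@@H]32)cc2c1OC[C@H]2C1CCOCC1` is not yet measured. It differs from compound 1 in one place: oxan-4-yl in place of pyridin-3-yl on a saturated ring carbon. Within the data shown here, with no single-change step among the measured compounds to rest on, the expected step of a number 0.20 log units higher from compound 1 to compound 3 (within the scatter) is small, upward, and near the edge of the scatter. Compound 3 is therefore estimated at 1.6, within a range from 1.1 to 2.2.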

Compound 3, distribution coefficient: 2.1
Estimate against measurement, compound 3: 0.50 log units below, within the range that was stated.
By their numbers in this assay, from the lowest: compound 1; then compound 3; then compound 2.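

In this assay this position gives its first readable single change: oxan-4-yl in place of pyridin-3-yl gives a number 0.70 log units higher from compound 1 to compound 3 (beyond the scatter) and so shows that the number here responds to the choice of ring. The two rings have the same heavy-atom count and hydrogen-bond acceptor count, yet one is aromatic and the other is not, with oxygen instead of nitrogen as the hetero atom. No measurement shown gives the reason for this step. This single pair cannot separate the loss of aromaticity from the change of hetero atom. Going by these compounds, how a piperidin-4-yl ring, a saturated amine, would behave on the same carbon also remains open.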